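The source may hold more compounds than are shown below. What is called first, only, known or untested is meant among the compounds shown, and "the series" means these compounds.

Measured so far:
compound 1, `CN(C)c1ccc2c(O)c(C(=O)O)cnc2c1`: 479000 nM in an assay on isolated protein with malate dehydrogenase, mitochondrial (Sus scrofa) as the target; a higher number here means a weaker inhibitor, a lower number a stronger inhibitor
compound 2, `CC(=O)c1ccc2c(O)c(C(=O)O)cnc2c1`: 912000 nM in this assay

Compound 2 and compound 1 lie within the scatter of each other; the step of a 1.9-fold higher number from compound 1 to compound 2 (0.28 log units; within the scatter), acetyl in place of dimethylamino on an aromatic carbon, says no more. Compound 3, `NS(=O)(=O)c1ccc2c(O)c(C(=O)O)cnc2c1`, differs from compound 2 by sulfamoyl in place of acetyl on an aromatic carbon. For the measured compounds named here, that single measured step is the only one bearing on this change, and it was small; no step shows a sulfamoyl group entering. Compound 3 is therefore expected near compound 2, the estimated step of a 1.1-fold lower number from compound 2 to compound 3 (0.06 log units; within the scatter) not beyond the scatter. For compound 3 the estimate in this assay is 800000 nM, range 300000 nM to 2500000 nM.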

Compound 3, half-maximal inhibitory concentration: 955000 nM
Compound 3: the middle estimate sits 1.2-fold (0.08 log units) below what was measured; measured number inside the range.
By their numbers in this assay, from the lowest: compounds 1, 2 and 3 (each within the scatter of the next).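

In this assay, sulfamoyl on this aromatic carbon, with its hydrogen-bond donor, gives a 1.0-fold higher number from compound 2 to compound 3 (0.02 log units; within the scatter), and in place of dimethylamino it gives a 2.0-fold higher number from compound 1 to compound 3 (0.30 log units; within the scatter). Dimethylamino, acetyl and sulfamoyl therefore all lie within the scatter of one another at this position. No measured evidence accounts for this flat result.

On these data alone, whether a primary amine or a longer alkyl chain here would move the number beyond the scatter remains open. So does the contribution of the hydroxyl and carboxylic acid on the shared core.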